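From Cyano to Acetyl on the Shared Core

The compounds below may be only part of what the source reports. "The series", "measured", "known", "first", "only" and "open" are said of these compounds alone.

Measured in a functional assay on MCF7 cells (Homo sapiens) for inhibition, read by MTT assay, with a stated time of 72 h; a higher number here means a weaker inhibitor of growth, a lower number a stronger inhibitor of growth:
- compound 1 `COC(=O)/C=C/C1=CC[C@H]2C(C)(C)CCC[C@]2(C)[C@H]1C=O`: 7000 nM
- compound 2 `CC1(C)CCC[C@]2(C)[C@@H](C=O)C(/C=C/C#N)=CC[C@@H]12`: 31000 nM

Of the two, compound 2 has the higher number, 31000 nM. Compound 3 `CC(=O)/C=C/C1=CC[C@H]2C(C)(C)CCC[C@]2(C)[C@H]1C=O` differs from it as follows: acetyl in place of cyano on a double-bonded chain carbon bound to a double-bonded chain carbon. Thus compound 3 carries acetyl where compound 2 carries cyano. Among the compounds with values here, one measured step bears on this change: a 4.4-fold higher number from compound 1 to compound 2 (0.65 log units; beyond the scatter), where cyano took the place of methoxycarbonyl. A step of similar size in the reverse direction is therefore expected in this assay, toward a lower number. The expected step is a 3.1-fold lower number from compound 2 to compound 3 (0.49 log units; beyond the scatter). The estimate for compound 3 is 10000 nM, with a range of 3500 nM to 28000 nM.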

Compound 3, concentration for 50% growth inhibition: 20000 nM
For compound 3 the middle estimate is 2.0-fold (0.30 log units) below the measured one; the measured number falls inside the stated range.
By their numbers in this assay, from the lowest: compound 1; then compounds 3 and 2 (each within the scatter of the next).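

In this assay acetyl and cyano at this place, on a double-bonded chain carbon bound to a double-bonded chain carbon, are not told apart (a 1.6-fold lower number from compound 2 to compound 3 (0.19 log units; within the scatter)). Methyl in place of methoxy on the carbonyl carbon gives a 2.9-fold higher number from compound 1 to compound 3 (0.46 log units; beyond the scatter), so compound 1 alone stands apart, its steps to both others lying beyond the scatter. Nothing available explains this result.

The compounds shown leave open whether the methoxy oxygen itself matters or whether a larger ester would serve as well. They also leave open how a carboxylic acid or an amide at this place would compare with compound 1.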